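Shortening the Ethyl Group Next to the Double-Bonded Nitrogen

The compounds below may be only part of what the source reports. "The series", "measured", "known", "first", "only" and "open" are said of these compounds alone.

Compound 2 `CC/N=C(\S)NCCCn1nc(-c2ccccc2)ccc1=O` was tested in a functional assay on the whole organism (stomach) with Rattus norvegicus as the target (a higher number here means that more compound is needed for the effect, a lower number that less compound is needed), and reaches only a limit of the assay, > 100 mg/kg. It does not stand alone there: the limit of > 100 mg/kg in this assay, at which 2 of the 3 values shown sit. Compound 1 `C/N=C(\S)NCCCCCn1nc(-c2ccccc2)ccc1=O`, which carries a methyl instead of the ethyl and a longer chain between the core and the sulfur-bearing group, gives 35.3 mg/kg. Compound 3 `C/N=C(/NC#N)NCCCn1nc(-c2ccccc2)cc(C)c1=O`, which carries a nitrile-bearing group in place of the sulfur and an extra methyl on its core, also reaches only the limit, > 100 mg/kg.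

Compound 4 `C/N=C(\S)NCCCn1nc(-c2ccccc2)ccc1=O` differs from compound 2 by hydrogen in place of methyl on a saturated chain carbon bound to a double-bonded nitrogen. For the measured compounds named here, the only measured step touching this region is an at least 2.8-fold higher number from compound 1 to compound 2 (0.45 log units; beyond the scatter), yet it alters the chain length at the same time, so its size cannot be credited to the methyl alone. With compound 2 sitting at a limit, no direction can be ruled out; the expected step of an at least 1.2-fold lower number from compound 2 to compound 4 (0.09 log units; that floor lies within the scatter) is therefore a modest move toward a lower number. Compound 4 is estimated at 80 mg/kg, within 30 mg/kg to 200 mg/kg, and may well reach only the limit again.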

Compound 4, dose for half-maximal effect: > 100 mg/kg
Compound 4 was reported as a limit; the forecaster's own chance of this, stated with the estimate: 45%; middle value at least 1.2-fold (0.09 log units) away from the limit.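

Hydrogen in place of methyl, which is the change from ethyl to methyl, leaves compound 4 at a limit of this assay, just like compound 2, so the step between these two cannot be read. With the methyl now held constant, the shorter chain alone goes with an at least 2.8-fold higher number from compound 1 to compound 4 (0.45 log units; beyond the scatter), a reading the earlier step could not give, as it changed ethyl to methyl at the same time. Among the compounds shown, a value that is not a limit appears only with the longer chain of compound 1: the limit of > 100 mg/kg in this assay, at which 3 of the 4 values shown sit.

Going by these compounds, whether ethyl on that longer chain would give a similar value stays open. So does the effect of a propyl group in place of the methyl, or of a still longer chain, in this assay.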